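Trifluoromethyl on the anilino ring across two cores

The compounds below may be only part of what the source reports. "The series", "measured", "known", "first", "only" and "open" are said of these compounds alone.

Compound 1 `COc1ccc(Cn2nc(-c3ccccc3)c3cc(C(=N)Nc4ccccc4)ncc32)cc1` gives 6300 nM in a functional assay on PC-3 cells (Homo sapiens) for cytotoxicity, read by MTT assay, with a stated time of 72 h; a lower number here means a stronger inhibitor, a higher number a weaker inhibitor. Compound 3 `COc1ccc(Cn2nc(-c3ccccc3)c3cc(C(=N)Nc4cccc(C(F)(F)F)c4)ncc32)cc1` carries trifluoromethyl in place of hydrogen on an aromatic carbon. In this assay compound 3 reaches only a limit of the assay, > 50000 nM. This gives an at least 7.9-fold higher number from compound 1 to compound 3 (0.89 log units; beyond the scatter). Compound 2 `N=C(Nc1ccccc1)c1cc2cn[nH]c2cn1` has a core whose difference from compound 1 is not broken down here; in this assay compound 2 has "not determined" (no result reported). Compound 4 `N=C(Nc1cccc(C(F)(F)F)c1)c1cc2cn[nH]c2cn1` differs from compound 2 by trifluoromethyl in place of hydrogen on an aromatic carbon, the same change as that from compound 1 to compound 3, at the same place. Because an at least 7.9-fold higher number from compound 1 to compound 3 (0.89 log units; beyond the scatter) weakened the larger core, a weak result is expected for compound 4 as well, estimated at 70000 nM in this assay. The expected range for compound 4 runs from 15000 nM to 300000 nM.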

Compound 4, half-maximal inhibitory concentration: > 50000 nM
Compound 4: a limit, no number (the forecaster's own chance of this, stated with the estimate: 70%); the middle value does not contradict the limit.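

No step can be read between compound 2 and compound 4: in this assay compound 4 gives only a limit, > 50000 nM, and compound 2 offers no number. The compounds shown leave open how far trifluoromethyl shifts the result on the core of compound 2.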